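A few compounds are considered here, and "the series" means these few. Any claim that something is new, unique, unknown or untested is made for them only; others in the source may bear on it.

Three compounds have been measured in a functional assay on UACC-62 cells (Homo sapiens) for cytotoxicity, read by sulforhodamine B assay, with a stated time of 48 h; a lower number here means a stronger inhibitor of growth, a higher number a weaker inhibitor of growth:

Compound 1, `ClCc1ccccc1Cn1cnc2c(Cl)nc(Cl)nc21`: 2630 nM
Compound 2, `ClCc1ccccc1Cn1cnc2c(Cl)ncnc21`: 6600 nM
Compound 3, `ClCc1ccc(Cn2cnc3nc(Cl)nc(Cl)c32)cc1`: 3160 nM

Compound 1 and compound 2 share a core and differ in one place, (hydrogen in place of chloro on an aromatic carbon). That change gave a 2.5-fold higher number from compound 1 to compound 2 (0.40 log units; beyond the scatter), so the compound without the chloro group is the weaker inhibitor of growth in this pair. Compound 3 is built from the same atoms as compound 1, joined differently; the difference between the two cores is not broken down here. What is known is that compound 3 and compound 1 give numbers within the usual scatter of each other, while compound 3 and compound 2 lie beyond it.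

Compound 4, `ClCc1ccc(Cn2cnc3ncnc(Cl)c32)cc1`, has not yet been measured. It differs from compound 3 by hydrogen in place of chloro on an aromatic carbon, the same change as from compound 1 to compound 2, at the same kind of place. Within the data shown here, the only guide is the step already seen with compound 1 and compound 2, a 2.5-fold higher number from compound 1 to compound 2 (0.40 log units; beyond the scatter). On that basis the step from compound 3 to compound 4 is expected to be a 2.5-fold higher number from compound 3 to compound 4 (0.40 log units; beyond the scatter). Compound 4 is therefore estimated at 7900 nM, with a likely range from 4000 nM to 16000 nM.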

Compound 4, concentration for total growth inhibition: 12000 nM
For compound 4 the middle estimate is 1.5-fold (0.18 log units) below the measured one; low and high end bracket the measured number.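

In this assay, hydrogen in place of chloro on the aromatic carbon between two ring nitrogen atoms gave a 3.8-fold higher number from compound 3 to compound 4 (0.58 log units; beyond the scatter) and so left compound 4 the weaker inhibitor of growth of this pair. On both cores the change pointed the same way, and the two steps agree in size within the scatter: the same change on two cores in this assay, a 2.5-fold higher number (0.40 log units; beyond the scatter) from compound 1 to compound 2 and a 3.8-fold higher number (0.58 log units; beyond the scatter) from compound 3 to compound 4, 1.5-fold (0.18 log units) apart, within the scatter of two such steps. Among these compounds, this rests on only two pairs, so it shows that the step carried across these two cores, but it does not show that the step would hold on any other core, and it does not explain why the number rises.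

The compounds shown leave open whether an amine or a methoxy group at that same place would give a lower or a higher number than chloro or hydrogen. They also leave open whether the step would keep its size on a core that carries a carboxylic acid.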